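The compounds below may be only part of what the source reports. "The series", "measured", "known", "first", "only" and "open" are said of these compounds alone.

In a physicochemical assay for lipophilicity, read by HPLC, measured as chromatographic lipophilicity, at pH 7.4 (on this read-out higher numbers stand for higher lipophilicity and lower numbers for lower lipophilicity), three compounds have been measured so far. Compound 1 (`Cc1ccc(C2CC=NN2C(=O)C(C)(C)C)cc1`) gives 6.4, compound 2 (`CC(C)(C)C(=O)N1N=CCC1c1ccccn1`) gives 3.5, and compound 3 (`O=C(C1CCN(C(=O)C(F)(F)F)CC1)N1N=CCC1c1ccccc1`) gives 4.9. Compound 3 therefore stands second highest of the three, above compound 2 and below compound 1, with both gaps beyond the scatter.

Compound 4 (`O=C(c1c[nH]nn1)N1CCC(C(=O)N2N=CCC2c2ccccc2)CC1`) has not yet been measured in this assay. It differs from compound 3 in one place: 1H-1,2,3-triazol-4-yl in place of trifluoromethyl on a carbonyl carbon. In words, 1H-1,2,3-triazol-4-yl stands in place of trifluoromethyl on a carbonyl carbon. Cut one bond further out, (trifluoromethyl)carbonyl gives way to (1H-1,2,3-triazol-4-yl)carbonyl.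

Within the data shown here, no two measured compounds differ in only one place, so the size of this change cannot be read from the existing data. The expectation rests on the structural difference alone, starting from compound 3 at 4.9, and it points to a lower number. The estimated step is a number 1.50 log units lower from compound 3 to compound 4 (beyond the scatter), expected to be downward and beyond the scatter. Compound 4 is expected to read about 3.4, with an estimated range from 2.7 to 4.1.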

Compound 4, distribution coefficient: 2
Estimate against measurement, compound 4: 1.40 log units above; measured number below the stated range.
By their numbers in this assay, from the lowest: compound 4; then compound 2; then compound 3; then compound 1.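

Among these compounds, this pair is the first in the set to differ in one place, so in this assay the size of a change on a carbonyl carbon whose other neighbour is an amide-type nitrogen in a ring can now be read directly: the exchange gives a number 2.90 log units lower from compound 3 to compound 4 (beyond the scatter) and counts as a large step. The position is therefore far from silent on this read-out, even though trifluoromethyl, with 4 heavy atoms, no ring and no hydrogen-bond donors or acceptors, gives way to 1H-1,2,3-triazol-4-yl, with only 5 heavy atoms but one five-membered aromatic ring, 1 hydrogen-bond donor and 2 hydrogen-bond acceptors. No separate measurement bears on what lies behind the size of this step.

The compounds shown leave open how much of the step goes with the arrival of 1H-1,2,3-triazol-4-yl and how much with the departure of trifluoromethyl, a split that a plain methyl group or a phenyl ring on the same carbonyl carbon could help to settle. Also open, from the compounds shown here alone, is whether the same exchange would move the number as far on a different core: a single pair cannot tell.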